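This account rests on a few compounds, and the source may have more. Where it says the series, first, only, none or still open, it means among the compounds named here.

In a functional assay on SW1573 cells (Homo sapiens) for antiproliferative activity, read by sulforhodamine B assay, with a stated time of 48 h (on this read-out lower numbers stand for stronger inhibition of growth and higher numbers for weaker inhibition of growth), compound 1 `CCCCCCCCCCCCCCC[C@@H](O)[C@@H](N)[C@@H](C)O` gives 17000 nM, compound 2 `CCCCCCCCCCCCCCC[C@@H](O)[C@@H](N)C(C)C` gives 7200 nM and compound 3 `CCCCCCCCC[C@@H](O)[C@@H](N)[C@@H](C)CC` gives 13000 nM. The value of compound 3 lies within the usual scatter of both the others, so these numbers cannot rank it against either one. Those two others do stand apart from each other: isopropyl in place of 1-hydroxyethyl gives a 2.4-fold lower number from compound 1 to compound 2 (0.37 log units; beyond the scatter), a modest step beyond the scatter.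

Compound 4 `CCCCCCCCCCCCCCC[C@@H](O)[C@@H](N)[C@@H](C)CC` keeps the rest of compound 3 and extends its chain, with this difference: hexyl in place of hydrogen on a saturated chain carbon, ten or more bonds along the chain from an oxygen on a saturated carbon. Going by the values given here, no measured step tests this change directly, and the one step available concerns a different group. The best guide is therefore indirect. The same long chain as in compound 4 is carried by compound 2, at 7200 nM, and by compound 1, at 17000 nM. These two values bracket the value of compound 3, so the longer chain gives no clear reason to expect a large shift, although neither compound carries the exact group found in compound 4. The expected change is small, within the scatter: a 1.6-fold lower number from compound 3 to compound 4 (0.21 log units; within the scatter). The estimated value for compound 4 is 8000 nM, with an expected range from 3500 nM to 18000 nM.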

Compound 4, concentration for 50% growth inhibition: 3400 nM
Beside the measured number, compound 4's estimate is 2.4-fold (0.37 log units) above it; measured number below the stated range.
By their numbers in this assay, from the lowest: compound 4; then compounds 2, 3 and 1 (each within the scatter of the next, the first and the last beyond it).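

Hexyl in place of hydrogen on a saturated chain carbon gives the first direct test of chain length in this assay: a 3.8-fold lower number from compound 3 to compound 4 (0.58 log units; beyond the scatter), so with this end group the longer chain does matter. With the long chain held constant, the other end of the molecule also counts, as methyl in place of hydrogen on a saturated chain carbon, three bonds along the chain from an amine nitrogen, gives a 2.1-fold lower number from compound 2 to compound 4 (0.33 log units; beyond the scatter), and ethyl in place of hydroxy on a saturated chain carbon bound to two saturated chain carbons gives a 5.0-fold lower number from compound 1 to compound 4 (0.70 log units; beyond the scatter). Compound 4 is therefore the strongest of the four here, with its steps to all three others beyond the scatter, and no accompanying measurement offers an explanation for these steps.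

The compounds shown leave open whether a chain longer than that of compound 4 would lower the number further, and whether lengthening the chain has a similar effect with other end groups. They also leave open how an amine or a carboxylic acid in place of that ethyl would read.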